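Chloro-Sulfamoylphenyl Replaces Carboxyphenyl on a Kinase Binder

This account rests on a few compounds, and the source may have more. Where it says the series, first, only, none or still open, it means among the compounds named here.

Measured compounds in an assay for binding affinity to dual specificity mitogen-activated protein kinase kinase 4 (Homo sapiens), read by KINOMEscan, tested at 100 nM; on this read-out lower numbers stand for a stronger effect and higher numbers for a weaker effect at the one concentration tested:
Compound 1 `CCCS(=O)(=O)Nc1ccc(F)c(C(=O)c2n[nH]c3ncc(-c4ccc(C(C)(C)C)cc4)cc23)c1F` gives 46%.
Compound 2 `CCCS(=O)(=O)Nc1ccc(F)c(C(=O)c2n[nH]c3ncc(-c4ccc(C(=O)O)cc4)cc23)c1F` gives 0.1%.

Compound 2 stands lowest of the two numbers in this assay; its nearest neighbour, compound 1, lies higher by a step beyond the scatter. Going by the values given here, the only measured step, a number 45.9 percentage points lower from compound 1 to compound 2 (beyond the scatter), shows how strongly the group on this aromatic carbon moves the read-out. Compound 3 `CCCS(=O)(=O)Nc1ccc(F)c(C(=O)c2n[nH]c3ncc(-c4ccc(S(N)(=O)=O)cc4Cl)cc23)c1F` differs from compound 2 in that same place: 2-chloro-4-sulfamoylphenyl in place of 4-carboxyphenyl on an aromatic carbon. Among the compounds with values here, no measured step covers a sulfamoyl or a chloro group, so the step from compound 1 to compound 2 bears only loosely on this change. Compound 2 already lies very low with 0.1%. For compound 3 the estimate in this assay is therefore 8%, within 0% to 45%. The expected step is a number 7.9 percentage points higher from compound 2 to compound 3 (within the scatter), most likely within the scatter, with the range allowing a moderate rise.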

Compound 3, a percentage reported as activity, at one concentration (the size of the read-out at that concentration, not a potency): 3.4%
For compound 3 the middle estimate is 4.6 percentage points above the measured one, within the range that was stated.
By their numbers in this assay, from the lowest: compounds 2 and 3 (each within the scatter of the next); then compound 1.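

In this assay, the change gives a number 3.3 percentage points higher from compound 2 to compound 3 (within the scatter), so at this position 2-chloro-4-sulfamoylphenyl and 4-carboxyphenyl cannot be told apart, even though the two groups share neither their heavy-atom count nor their hydrogen-bond acceptor count. Set against 4-(tert-butyl)phenyl, the entering group gives a number 42.6 percentage points lower from compound 1 to compound 3 (beyond the scatter), which shows that a low number at this position is not tied to the 4-carboxyphenyl group alone. No evidence at hand accounts for why these two different groups read alike.

From the compounds shown here alone, the chloro and sulfamoyl groups enter together, so what each contributes on its own remains open. Also open, going by these compounds, is how an amine or a methylsulfonyl group in place of the sulfamoyl group would read at this position.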